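Diphenylmethylpiperidines with aryl-linked propyl chains: working notes

The source may hold more compounds than are shown below. What is called first, only, known or untested is meant among the compounds shown, and "the series" means these compounds.

Measured so far:
compound 1 `COc1cc(C(C)=O)ccc1OCCCN1CCC(C(c2ccc(C)cc2)c2ccc(C)cc2)CC1`: 15.9 nM
compound 2 `COc1cc(C(C)=O)ccc1OCCCN1CCC(C(NC(C)=O)(c2ccc(F)cc2)c2ccc(F)cc2)CC1`: 63.1 nM
compound 3 `Fc1ccc(C(c2ccc(F)cc2)C2CCN(CCCOc3ccc(Cl)cc3)CC2)cc1`: 2 nM

All three values come from a functional assay (aorta) with Oryctolagus cuniculus as the target; on this read-out higher numbers stand for weaker binding and lower numbers for tighter binding. Compound 3 holds the lowest number of the three; compound 1 sits at a higher number, beyond the scatter, and compound 2 at a higher number still, also beyond the scatter. Compound 1 and compound 2 share one aryloxy chain end that differs from that of compound 3, and both fall short of it, so the chain end appears to matter, though with three compounds no firm pattern can be drawn.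

Compound 4 `O=S(=O)(CCCN1CCC(C(c2ccc(F)cc2)c2ccc(F)cc2)CC1)c1ccccc1` has not yet been measured. It differs from compound 3 in one place: phenylsulfonyl in place of 4-chlorophenoxy on a saturated chain carbon, three bonds along the chain from an amine nitrogen in a ring. Within the data shown here, no measured pair shows this change, so the size of the step is open. For compound 4 the expected value in this assay is 8 nM, within a range of 2 nM to 40 nM. The step that this estimate means, a 4.0-fold higher number from compound 3 to compound 4 (0.60 log units; beyond the scatter), is expected to be a moderate move towards a higher number, somewhat beyond the scatter, with a real chance that it stays within it.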

Compound 4, dissociation constant: 20 nM
Beside the measured number, compound 4's estimate is 2.5-fold (0.40 log units) below it, within the range that was stated.
By their numbers in this assay, from the lowest: compound 3; then compounds 1 and 4 (each within the scatter of the next); then compound 2.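

In this assay, among these compounds, phenylsulfonyl in place of 4-chlorophenoxy on a saturated chain carbon, three bonds along the chain from an amine nitrogen in a ring, gives a 10-fold higher number from compound 3 to compound 4 (1.00 log units; beyond the scatter) and is the first change read in one place only. This position therefore bears on the number with the rest of the molecule held the same, and here the aryl ether with its chlorine is the better of the two chain ends. Nothing available explains the size of this step.

Still open, going by these compounds, is how much of the step belongs to the sulfonyl link and how much to the loss of chlorine, as the two change together. A 4-chlorophenylsulfonyl or an unsubstituted phenoxy chain end would separate them, and a longer chain would test how far the aryl end can sit from the ring nitrogen.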